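Formyl in Place of Methylsulfonyl on the Oxazole Ketone Series

This account rests on a few compounds, and the source may have more. Where it says the series, first, only, none or still open, it means among the compounds named here.

Compound 1, `O=C(CCCCCCc1ccccc1)c1nnn[nH]1`: in an assay on HEK-293T cells for inhibition of diacylglycerol lipase-alpha (Homo sapiens), read by colorimetric assay (a higher number here means a weaker inhibitor, a lower number a stronger inhibitor), compound 1 gives > 10000 nM; > 10000 nM (2 entries), which is a limit of the assay rather than a number.
Compound 2, `CC(=O)c1coc(C(=O)CCCCCCc2ccccc2)n1`: in this assay compound 2 gives 123 nM.
Compound 3, `CS(=O)(=O)c1coc(C(=O)CCCCCCc2ccccc2)n1`: in this assay compound 3 gives 389 nM.

Going by the values given here, compound 3 therefore carries the highest of the numbers measured so far, so it is the weaker of the measured inhibitors; compound 2 sits below it by a 3.2-fold higher number from compound 2 to compound 3 (0.50 log units; beyond the scatter), a modest step that lies beyond the usual scatter. Compound 1 is left aside, since only a limit is known for it.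

Compound 4, `O=Cc1coc(C(=O)CCCCCCc2ccccc2)n1`, differs from compound 3 in one place: formyl in place of methylsulfonyl on an aromatic carbon. Among the compounds with values here, only one measured step bears on this change, the one from acetyl to methylsulfonyl, a 3.2-fold higher number from compound 2 to compound 3 (0.50 log units; beyond the scatter), which raised the number. The formyl of compound 4 is, like acetyl, a carbonyl on the same ring position, so the move from methylsulfonyl to formyl is expected to roughly undo that step and lower the number, by about a 2.6-fold lower number from compound 3 to compound 4 (0.41 log units; beyond the scatter).

Compound 4 is thus expected to give about 150 nM in this assay, most likely between 45 nM and 600 nM.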

Compound 4, half-maximal inhibitory concentration: 1510 nM
Compound 4: middle estimate off by 10-fold (1.00 log units), on the low side, outside the stated range (above it).
By their numbers in this assay, from the lowest: compound 2; then compound 3; then compound 4.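

At this aromatic carbon of the ring, formyl does not behave as a smaller stand-in for acetyl: in this assay the change gives a 3.9-fold higher number from compound 3 to compound 4 (0.59 log units; beyond the scatter) and so moves the number up, not back down. The sharper finding is that removing only the methyl from the carbonyl carbon gives a 12-fold higher number from compound 2 to compound 4 (1.09 log units; beyond the scatter) and is the largest step among these compounds, so two groups that both place a carbonyl on this ring position are far from interchangeable, and what is attached to that carbonyl carbon matters a great deal. Among the three compounds with single numbers, compound 2 with acetyl now has the lowest number, and no measurement available here explains the gap between acetyl and formyl.

As far as these compounds go, it remains open whether a longer acyl group such as propanoyl would lower the number further than acetyl does, and how an amide or a carboxylic acid on the same aromatic carbon would compare. Also unresolved is whether the order of acetyl, methylsulfonyl and formyl would hold with a shorter chain in place of the one ending in phenyl.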